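Homologating the Cycloalkyl Amine: From Compound 1 to Compound 4

This account rests on a few compounds, and the source may have more. Where it says the series, first, only, none or still open, it means among the compounds named here.

Compound 1 `c1ccc(Cn2nnc3c(NC4CCCCC4)ncnc32)cc1`: 121 nM
Compound 2 `Clc1ccccc1Cn1nnc2c(NC3CCCC3)ncnc21`: 21 nM
Compound 3 `CC1CCCC(Nc2ncnc3c2nnn3Cc2ccccc2Cl)C1`: 102 nM

Of the compounds shown here, three sharing one core have been measured in an assay on cell membranes for binding affinity to adenosine receptor A1 (Bos taurus), read by radioligand binding; a higher number here means a weaker inhibitor, a lower number a stronger inhibitor. Compound 1 stands at the highest of the three numbers; compound 3 sits close to it, within the scatter, while compound 2 lies well apart with a clearly lower number. Within the data shown here, the only single-point step among them is a 4.9-fold higher number from compound 2 to compound 3 (0.69 log units; beyond the scatter), a modest loss on moving from a smaller ring to a larger, methyl-bearing one.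

Compound 4 `c1ccc(Cn2nnc3c(NCC4CCCCC4)ncnc32)cc1` differs from compound 1 in one place: cyclohexylmethyl in place of cyclohexyl on a nitrogen on an aromatic ring. Among the measured compounds shown here, no measured pair shows exactly this insertion of a methylene between the ring nitrogen and the carbocycle, so the step from compound 2 to compound 3 bears on it only loosely, as a sign that changing the bulk on this nitrogen moves this assay by modest amounts rather than large ones. On that basis compound 4 is expected to give a somewhat higher number than compound 1, an estimated step of a 2.5-fold higher number from compound 1 to compound 4 (0.39 log units; beyond the scatter), with the possibility of no change beyond the scatter not excluded. The estimate for compound 4 in this assay is 300 nM, expected to fall between 100 nM and 1000 nM.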

Compound 4, inhibition constant: 2790 nM
Compound 4: middle estimate off by 9.3-fold (0.97 log units), on the low side, outside the stated range (above it).
By their numbers in this assay, from the lowest: compound 2; then compounds 3 and 1 (each within the scatter of the next); then compound 4.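

In this assay, among these compounds, the group on this nitrogen proves far less forgiving than the earlier compounds suggested: cyclohexylmethyl in place of cyclohexyl gives a large step (a 23-fold higher number from compound 1 to compound 4 (1.36 log units; beyond the scatter)), whereas the one step seen before was modest (a 4.9-fold higher number from compound 2 to compound 3 (0.69 log units; beyond the scatter)). The six-membered carbon ring is the same in both groups, and neither group has hydrogen-bond donors or acceptors, so the methyl link of cyclohexylmethyl is the only new part, and on this pair that small change is enough to carry the number far beyond the scatter. Nothing measured here accounts for the size of this loss.

From the compounds shown here alone, it remains open whether a longer chain, such as 2-cyclohexylethyl, would take the number higher still, or whether benzyl on this nitrogen, with a phenyl ring in place of the cyclohexyl ring, would behave like cyclohexylmethyl. Among the compounds shown here, also open is whether cyclopentylmethyl in place of cyclopentyl on compound 2 would carry a comparable cost, which would show whether this loss extends beyond the single pair.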